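The source may hold more compounds than are shown below. What is called first, only, known or untested is meant among the compounds shown, and "the series" means these compounds.

Measured compounds in a functional assay on BEAS-2B cells (Homo sapiens) for inhibition, read by MTT assay, with a stated time of 72 h; on this read-out lower numbers stand for stronger inhibition and higher numbers for weaker inhibition:
- compound 1, `C=C(c1ccc(F)c(F)c1)C1COC2(CCCC2)OO1`, gives 73600 nM
- compound 2, `C=C(c1ccc(Cl)cc1Cl)C1COC2(CCCCC2)OO1`, gives 16700 nM
- compound 3, `C=C(c1ccc(Cl)c(Cl)c1Cl)C1COC(C)(C)OO1`, gives 10200 nM

Among these three, compound 1 shows the highest number in this assay. Its nearest neighbour on the scale is compound 2, whose value lies beyond the scatter below that of compound 1; compound 3 is further away still, also beyond the scatter. Among the compounds with values here, no pair of these three differs in a single place, so no step between measured compounds can be read off.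

The account now turns to compound 4, `C=C(c1ccc(OC)c(F)c1)C1COC2(CCCC2)OO1`, which shares the core of compound 1 and differs from it by methoxy in place of fluoro on an aromatic carbon. Within the data shown here, there is no comparable step among the measured compounds, and the direction of this change is uncertain. The expected step is a modest one, a 1.5-fold lower number from compound 1 to compound 4 (0.17 log units; within the scatter), toward a somewhat lower number, within or only slightly beyond the scatter. Compound 4 is therefore expected to give about 50000 nM in this assay, with a range from 15000 nM to 150000 nM.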

Compound 4, half-maximal inhibitory concentration: 55800 nM
The estimate for compound 4 lay 1.1-fold (0.05 log units) below the measured number; the measured number falls inside the stated range.
By their numbers in this assay, from the lowest: compounds 3 and 2 (each within the scatter of the next); then compounds 4 and 1 (each within the scatter of the next).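

In this assay, within the data shown here, the exchange at this position provides the first step that can be read: methoxy in place of fluoro, on an aromatic carbon ortho to a fluoro group and para to a large group, gives a 1.3-fold lower number from compound 1 to compound 4 (0.12 log units; within the scatter) on the core of compound 1. On this core, therefore, the position accepts methoxy, with its hydrogen-bond acceptor, without a difference that can be told from the scatter. Nothing available bears on what lies behind this result.

On these data alone, whether an amine, a carboxylic acid or a longer chain such as ethoxy at this position would also stay within the scatter remains open. Equally open, as far as these compounds go, is whether the same exchange would read alike on the cores of compound 2 and compound 3.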